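Cytotoxicity notes: piperidin-1-yl replacing methylcarbamoyl in compound 4

The source may report more compounds than this note shows. Statements on the series, on what has been measured and on what is new or still open speak of the compounds shown alone.

Measured in a toxicity assay on NIH3T3 cells (Mus musculus) for cytotoxicity, read by resazurin assay; on this read-out lower numbers stand for an effect already at smaller amounts and higher numbers for an effect only at larger amounts of compound:
compound 1 `CNC(=O)c1ccc(NCc2cncn2Cc2ccc(-c3ccccc3)cc2N)cc1-c1ccccc1` gives > 1000 nM, a limit of the assay.
compound 2 `c1ccc(-c2ccc(Cn3cncc3CNc3ccc(-c4ccccc4)c(-c4ccccc4)c3)cc2)cc1` gives > 10000 nM, a limit of the assay.
compound 3 `CNC(=O)c1ccc(NCc2cncn2Cc2ccc(-c3ccccc3)cc2)cc1-c1ccccc1` gives > 1000 nM, a limit of the assay.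

Among the measured compounds shown here, compound 3 therefore stands only at a limit in this assay, and the two other values shown are limits as well, so no compound in the set has a number. Two values sit at the limit of > 1000 nM in this assay, at which 2 of the 3 values shown sit, and one at the limit of > 10000 nM in this assay, at which 1 of the 3 values shown sits. The two steps that reach compound 3 are a step that the two limits leave unreadable from compound 1 to compound 3 and a step that the two limits leave unreadable from compound 2 to compound 3; neither size can be read, since both ends are limits.

Compound 4 `c1ccc(-c2ccc(Cn3cncc3CNc3ccc(N4CCCCC4)c(-c4ccccc4)c3)cc2)cc1` is not yet measured in this assay. It differs from compound 3 by piperidin-1-yl in place of methylcarbamoyl on an aromatic carbon. For the measured compounds named here, no measured step bears readably on this change: the steps into compound 3 show only that all three compounds sit at limits. The expectation for compound 4 is therefore that it, too, reaches no number in this assay, and the estimated step that the limit leaves unreadable from compound 3 to compound 4 is expected to be none beyond the scatter. Compound 4 is estimated at 10000 nM, with a range from 2000 nM to 50000 nM, most likely reported again as a limit.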

Compound 4, half-maximal effective concentration: > 1000 nM
Compound 4: no number, only a limit; the forecaster's own chance of this, stated with the estimate: 80%; the middle value is on the limit's open side.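

In this assay, compound 4 gives > 1000 nM, which is a limit of the assay. No new step can be read: compound 4 and its neighbours compound 2 and compound 3 all stand at limits. The compounds shown leave open at what concentration any of them reaches a half-maximal effect, and whether piperidin-1-yl in place of methylcarbamoyl changes that concentration at all.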